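The source may hold more compounds than are shown below. What is called first, only, known or untested is meant among the compounds shown, and "the series" means these compounds.

Working notes on the series sharing one core. Compound 3 `O=C(CI)NCCCNc1ncnc2c1ncn2[C@@H]1O[C@H](COP(=O)(O)OP(=O)(O)OP(=O)(O)O)[C@@H](O)[C@H]1O`, compound 2 `O=C(CI)NCCCCNc1ncnc2c1ncn2[C@@H]1O[C@H](COP(=O)(O)OP(=O)(O)OP(=O)(O)O)[C@@H](O)[C@H]1O` and compound 1 `O=C(CI)NCCCCC(=O)NCCCCCCNc1ncnc2c1ncn2[C@@H]1O[C@H](COP(=O)(O)OP(=O)(O)OP(=O)(O)O)[C@@H](O)[C@H]1O` are measured. In an assay on isolated protein for inhibition of hexokinase-2 (Rattus norvegicus), with a stated time of 6 h, tested at 10 mM (on this read-out higher numbers stand for more inhibition at the one concentration tested (going by the name of the read-out) and lower numbers for less inhibition), compound 3 gives 0%, compound 2 gives 0% and compound 1 gives 0%; compound 3 is level with both at the digits shown. Among the compounds with values here, the single one-place step, no change at the digits printed from compound 2 to compound 3 (within the scatter), lies within the scatter. Compound 4 `O=C(CI)NCCCCCCCNc1ncnc2c1ncn2[C@@H]1O[C@H](COP(=O)(O)OP(=O)(O)OP(=O)(O)O)[C@@H](O)[C@H]1O` awaits measurement; it differs from compound 3 by 4-(((iodomethyl)carbonyl)amino)butyl in place of ((iodomethyl)carbonyl)amino on a saturated chain carbon, three bonds along the chain from a nitrogen on an aromatic ring. Within the data shown here, only the step from compound 2 to compound 3 bears on a change of this kind, and it showed nothing; compound 1 shows no inhibition either. In this assay the expected step is no change at the digits printed from compound 3 to compound 4 (within the scatter), nothing beyond the scatter. Compound 4 is estimated at 0%, range 0% to 10%.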

Compound 4, a percentage reported as inhibition, at one concentration (the size of the read-out at that concentration, not a potency): 30%
Compound 4: middle estimate off by 30 percentage points, on the low side; measured number outside the range, above it.
By their numbers in this assay, from the lowest: compounds 1, 2 and 3 (each within the scatter of the next); then compound 4.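

In this assay the flat series now shows a response at this position: 4-(((iodomethyl)carbonyl)amino)butyl in place of ((iodomethyl)carbonyl)amino gives a number 30 percentage points higher from compound 3 to compound 4 (beyond the scatter) and the next shorter chain gives a number 30 percentage points higher from compound 2 to compound 4 (beyond the scatter) so chain length here can matter. Length alone does not order the series, since replacing the group of 12 heavy atoms in compound 1 with the group of 6 gives a number 30 percentage points higher from compound 1 to compound 4 (beyond the scatter) and compound 1 goes against any simple rise with length.

No measurement at hand accounts for the rise. Open, as far as these compounds go, is whether a longer unbroken chain, or a chloromethyl carbonyl group in place of the iodomethyl carbonyl group, would hold or raise the number.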